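A few compounds are considered here, and "the series" means these few. Any claim that something is new, unique, unknown or untested is made for them only; others in the source may bear on it.

Compound 1 `C/C(=N\Nc1nc(-c2ccc(C)cc2)cs1)c1sc(C)nc1C` is the starting point. In a toxicity assay on THP-1 cells (Homo sapiens) for cytotoxicity, read by MTT assay (on this read-out higher numbers stand for weaker inhibition of growth and lower numbers for stronger inhibition of growth), compound 1 gives > 100 ug/mL, which is a limit of the assay and not a number. Compound 2 `COc1ccc(-c2csc(N/N=C(\C)c3sc(C)nc3C)n2)cc1` carries a methoxy in place of methyl on an aromatic carbon. In this assay compound 2 gives > 100 ug/mL, again a limit rather than a number. The step from compound 1 to compound 2 a step that the two limits leave unreadable from compound 1 to compound 2 cannot be read, because the limit of > 100 ug/mL in this assay, at which 2 of the 2 values shown sit, leaves the size of any difference between the two hidden.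

Compound 3 `C/C(=N\Nc1nc(-c2ccc(C)cc2)cs1)c1sc(-c2ccccc2)nc1C` differs from compound 1 in phenyl in place of methyl on an aromatic carbon. No measured step speaks to this change: the only step shown, from methyl to methoxy on a different aromatic carbon, is unreadable, and both measured compounds sit at the same limit. With nothing pointing in either direction, compound 3 is expected to remain near that limit, with the expected step from compound 1 to compound 3 a number no higher from compound 1 to compound 3 (the limit leaves the size open) being none beyond the scatter. The estimate for compound 3 in this assay is 100 ug/mL, with a range from 30 ug/mL to 300 ug/mL.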

Compound 3, concentration for 50% growth inhibition: > 100 ug/mL
Compound 3: no number, only a limit; the forecaster's own chance of this, stated with the estimate: 65%; the middle value lies on the limit itself.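

In this assay compound 3 gives > 100 ug/mL, which is again a limit and not a number. The step between compound 1 and compound 3 therefore cannot be read, because the values stop at the same limit: the limit of > 100 ug/mL in this assay, at which 3 of the 3 values shown sit.

The compounds shown leave open how strongly each inhibits cell growth, and whether methoxy or phenyl in place of methyl changes it at all.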